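From 4-methoxyphenyl to 2,3,4-trimethoxyphenyl: an expected step

A few compounds are considered here, and "the series" means these few. Any claim that something is new, unique, unknown or untested is made for them only; others in the source may bear on it.

In a functional assay on MCF7 cells (Homo sapiens) for cytotoxicity, read by MTT assay, with a stated time of 72 h (on this read-out lower numbers stand for stronger inhibition and higher numbers for weaker inhibition), compound 1 `O=C(N/N=C/c1ccc(F)cc1)Nc1cc2c(Nc3ccc(F)c(Cl)c3)ncnc2cc1O[C@H]1CCOC1` gives 28200 nM and compound 2 `COc1ccc(/C=N/NC(=O)Nc2cc3c(Nc4ccc(F)c(Cl)c4)ncnc3cc2O[C@H]2CCOC2)cc1` gives 27300 nM on the same scale. Among the compounds with values here, compound 2 therefore stands level with compound 1, the only other compound measured so far. Compound 3 `COc1ccc(/C=N/NC(=O)Nc2cc3c(Nc4ccc(F)c(Cl)c4)ncnc3cc2O[C@H]2CCOC2)c(OC)c1OC` differs from compound 2 by 2,3,4-trimethoxyphenyl in place of 4-methoxyphenyl on a carbon with a double bond to nitrogen and so carries 2,3,4-trimethoxyphenyl in place of 4-methoxyphenyl on a carbon with a double bond to nitrogen. Within the data shown here, only one measured step bears on this: methoxy in place of fluoro on an aromatic carbon, which gave a 1.0-fold lower number from compound 1 to compound 2 (0.01 log units; within the scatter) as its result. Among the measured compounds shown here, no measurement yet shows what added methoxy groups do, so in this assay no step beyond the scatter is expected, in either direction. The expected step is a 1.1-fold lower number from compound 2 to compound 3 (0.06 log units; within the scatter) as a best guess. For compound 3 the estimated value is 24000 nM with an expected range from 10000 nM to 50000 nM.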

Compound 3, half-maximal inhibitory concentration: 33800 nM
For compound 3 the middle estimate is 1.4-fold (0.15 log units) below the measured one, within the range that was stated.
By their numbers in this assay, from the lowest: compounds 2, 1 and 3 (each within the scatter of the next).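

In this assay, going from 4-methoxyphenyl to 2,3,4-trimethoxyphenyl on the carbon with a double bond to nitrogen gives a 1.2-fold higher number from compound 2 to compound 3 (0.09 log units; within the scatter), so a clearly larger group with more methoxy substituents leaves the read-out unchanged within the scatter. Putting the same group in place of the 4-fluorophenyl gives a 1.2-fold higher number from compound 1 to compound 3 (0.08 log units; within the scatter), so all three aromatic groups tried at this position cannot be told apart in this assay. Nothing at hand explains why the read-out tolerates these changes.

On these data alone, all three compounds carry a substituted phenyl ring at this place, so the effect of an amine, a carboxylic acid or a longer alkyl chain there remains open. As far as these compounds go, whether any change at this position can move the number beyond the scatter also remains open.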